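A few compounds are considered here, and "the series" means these few. Any claim that something is new, unique, unknown or untested is made for them only; others in the source may bear on it.

Compound 1, `CNC(=O)c1cc(C(=O)N[C@H]2CC[C@H](O)CC2)c([C@@H](C)c2ccccc2Cl)o1`: 3.1
Compound 2, `CNC(=O)c1cc(C(=O)NC2CC2)cn([C@@H](C)c2ccccc2)c1=O`: 3.3
Compound 3, `CC(=O)Nc1c(F)cc(C(=O)N[C@H]2CC[C@H](O)CC2)cc1O[C@@H](C)c1ccccc1`: 2.8

These three numbers come from a physicochemical assay for lipophilicity; a higher number here means a more lipophilic compound, a lower number a more polar compound. Compound 1 lies within the usual scatter of both compound 2 and compound 3, so the three cannot be told apart in this assay. Compound 4, `CNC(=O)c1cc(C(=O)N[C@H]2CC[C@H](O)CC2)c([C@@H](C)c2ccccc2)o1`, has not yet been measured. It differs from compound 1 in one place: hydrogen in place of chloro on an aromatic carbon. The chloro leaves an aromatic carbon of a six-membered aromatic ring of carbon only, ortho to a large group, and hydrogen enters. Among the compounds with values here, no pair of measured compounds shows this change on its own, so its size must be estimated. The expected step is a fall beyond the scatter: a number 0.70 log units lower from compound 1 to compound 4 (beyond the scatter). Compound 4 is thus expected to give about 2.4, between 2 and 2.8.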

Compound 4, distribution coefficient: 2.8
Beside the measured number, compound 4's estimate is 0.40 log units below it; low and high end bracket the measured number.
By their numbers in this assay, from the lowest: compounds 3, 4, 1 and 2 (each within the scatter of the next, the first and the last beyond it).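

Within the data shown here, the pair of compound 1 and compound 4 gives the first direct reading of hydrogen in place of chloro on this aromatic carbon, ortho to a large group: the step is a number 0.30 log units lower from compound 1 to compound 4 (within the scatter) in this assay and stands alone. On this single pair, the two groups cannot be told apart at this position. Nothing measured here explains the result.

A single pair cannot show whether bromo, methoxy or nitrile on the same carbon would also stay within the scatter. It also leaves open whether chloro on another carbon of this ring would read the same way.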